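The source may report more compounds than this note shows. Statements on the series, on what has been measured and on what is new or still open speak of the compounds shown alone.

Compound 1 `CC(C)c1c(OC2CCCCC2C)cc(Cc2ccc(Cl)cc2)[nH]c1=O`: 84000 nM
Compound 2 `CC(C)c1c(Cc2ccccc2)n(COCc2ccccc2)c(=O)[nH]c1=O`: 84600 nM

In an ADME assay on MT4 cells (Homo sapiens) for cytotoxicity, read by XTT assay, with a stated time of 3 days (a higher number here means that more compound is tolerated, a lower number that less compound is tolerated), compound 1 and compound 2 lie within the usual scatter of each other, so the two cannot be ranked, even though their structures differ. Compound 3 `Cc1ccc(Cc2cc(OC3CCCCC3C)c(C(C)C)c(=O)[nH]2)cc1` has not yet been measured. It keeps the core of compound 1 and changes one group: methyl in place of chloro on an aromatic carbon. This puts methyl in place of chloro on an aromatic carbon, para to a large group, so 4-chlorobenzyl becomes 4-methylbenzyl. Within the data shown here, no two measured compounds differ in just one place, so the data offer no direct guide to this swap. Among the measured compounds shown here, the only anchor is compound 1 at 84000 nM, and no step in this assay beyond the scatter is expected. The estimated step is small: a 1.0-fold higher number from compound 1 to compound 3 (0.02 log units; within the scatter). For compound 3 the expected value is 88000 nM, with an estimated range of 40000 nM to 190000 nM.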

Compound 3, half-maximal cytotoxic concentration: 112000 nM
For compound 3 the middle estimate is 1.3-fold (0.10 log units) below the measured one, within the range that was stated.
By their numbers in this assay, from the lowest: compounds 1, 2 and 3 (each within the scatter of the next).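

Among these compounds, this pair is the first in the set to differ in only one place, so it gives the first direct reading of this change in this assay. Putting methyl in place of chloro on the aromatic carbon, which turns 4-chlorobenzyl into 4-methylbenzyl, gives a 1.3-fold higher number from compound 1 to compound 3 (0.12 log units; within the scatter), so the two groups cannot be told apart at this position. Nothing available here offers an explanation for this result.

On these data alone, whether a different kind of group on this aromatic carbon, such as an amine, a carboxylic acid or a longer chain, would shift the number beyond the scatter remains open. Also open, as far as these compounds go, is whether the same swap would read alike on a different core, such as that of compound 2.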